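Trifluoromethyl for Methylsulfanyl on a Fused Triazole Core

The source may hold more compounds than are shown below. What is called first, only, known or untested is meant among the compounds shown, and "the series" means these compounds.

Compound 1 `CSc1nc2n(n1)C(c1ccc(O)cc1O)C([N+](=O)[O-])=NN2`: 201000 nM
Compound 2 `CSc1nc2n(n1)C(O)C([N+](=O)[O-])=NN2`: 99000 nM

In an ADME assay on MDCK cells (Canis lupus familiaris) for cytotoxicity (a lower number here means that less compound is tolerated, a higher number that more compound is tolerated), compound 2 stands lowest of the two numbers, and compound 1 lies higher, beyond the scatter. Compound 3 `O=[N+]([O-])C1=NNc2nc(C(F)(F)F)nn2C1O` differs from compound 2 by trifluoromethyl in place of methylsulfanyl on an aromatic carbon. Among the measured compounds shown here, no measured pair carries this change, so nothing in the data tells its size or direction in this assay. The expected step is a 1.1-fold lower number from compound 2 to compound 3 (0.04 log units; within the scatter), which is not expected to exceed the scatter in either direction. Compound 3 is therefore estimated at 90000 nM, with a range from 40000 nM to 200000 nM.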

Compound 3, half-maximal cytotoxic concentration: 40000 nM
Estimate against measurement, compound 3: 2.3-fold (0.35 log units) above; measured number inside the range.
By their numbers in this assay, from the lowest: compound 3; then compound 2; then compound 1.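

In this assay this position proves sensitive to its substituent: trifluoromethyl in place of methylsulfanyl on the aromatic carbon gives a 2.5-fold lower number from compound 2 to compound 3 (0.39 log units; beyond the scatter) and so moves the number beyond the scatter. The earlier compounds shown here all carried methylsulfanyl here and could not show this. Nothing shown gives a reason for the step. As far as these compounds go, it remains open whether an amine or a longer alkylsulfanyl chain on this carbon would hold the number of compound 2. From the compounds shown here alone, whether the same change would give a similar step on compound 1 also remains open.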